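The source may hold more compounds than are shown below. What is called first, only, known or untested is meant among the compounds shown, and "the series" means these compounds.

Among the measured compounds shown here, compound 2 `N#CC1=C(N)Oc2c(N)cc3nc4ccccc4nc3c2C12C(=O)N(Cc1cnnn1-c1cc(Cl)ccc1Cl)c1ccccc12` stands in a functional assay on A549 cells (Homo sapiens) for antiproliferative activity, read by MTT assay, with a stated time of 48 h (a higher number here means a weaker inhibitor, a lower number a stronger inhibitor), at 10900 nM, with compound 1 `Cc1cccc(-n2nncc2CN2C(=O)C3(C(C#N)=C(N)Oc4c(N)cc5nc6ccccc6nc5c43)c3ccccc32)c1` at 12300 nM as its only comparison; the step of a 1.1-fold lower number from compound 1 to compound 2 (0.05 log units; within the scatter) sits within the scatter, so the two compounds are indistinguishable on these numbers. Compound 3 `N#CC1=C(N)Oc2c(N)cc3nc4ccccc4nc3c2C12C(=O)N(Cc1cnnn1-c1ccc(Cl)cc1[N+](=O)[O-])c1ccccc12` differs from compound 2 by 4-chloro-2-nitrophenyl in place of 2,5-dichlorophenyl on an aromatic nitrogen. For the measured compounds named here, the single measured step that bears on this change, the earlier exchange of one aryl group on the same aromatic nitrogen, moved the number only within the scatter, so the expected step of a 1.0-fold higher number from compound 2 to compound 3 (0.00 log units; within the scatter) is none beyond the scatter. Compound 3 is therefore estimated at 11000 nM, in the range 5500 nM to 22000 nM.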

Compound 3, half-maximal inhibitory concentration: > 50000 nM
Compound 3 gave a limit, no number; the forecaster's own chance of this, stated with the estimate: 5%; at least 4.5-fold (0.65 log units) between middle value and limit.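

The aryl group on this aromatic nitrogen can therefore matter in this assay: the earlier exchange stayed within the scatter, whereas 4-chloro-2-nitrophenyl gives an at least 4.5-fold higher number from compound 2 to compound 3 (0.66 log units; beyond the scatter) and an at least 4.0-fold higher number from compound 1 to compound 3 (0.60 log units; beyond the scatter). Compound 3 gave a limit of the assay, not a number: the limit of > 50000 nM in this assay, at which 1 of the 3 values shown sits.

The nitro group and the different chlorine pattern enter together in compound 3, and the compounds shown do not separate the two. Also open, going by these compounds, is whether an amine in place of the nitro group would bring the number back towards that of compound 2.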